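This account rests on a few compounds, and the source may have more. Where it says the series, first, only, none or still open, it means among the compounds named here.

Compound 3 `COc1cccc(N2CC(c3nc(-c4cccc(Cl)c4)no3)CC2=O)c1` stands at the edge of what an in vitro functional assay on HEK293-A cells for positive allosteric modulation of metabotropic glutamate receptor 5 (Homo sapiens), read by FLIPR and calcium flux (a higher number here means that more compound is needed for the effect, a lower number that less compound is needed), can report: in this assay compound 3 gives > 10000 nM, which is a limit of the assay rather than a measured number, (the limit of > 10000 nM in this assay, at which 1 of the 3 values shown sits). Compound 4 `O=C1CC(c2nc(-c3cccc(Cl)c3)no2)CN1c1ccc(Cl)cc1` differs from compound 3 in one place: 4-chlorophenyl in place of 3-methoxyphenyl on an amide-type nitrogen in a ring.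

Going by the values given here, the only measured step, a 28-fold higher number from compound 1 to compound 2 (1.45 log units; beyond the scatter), alters a different part of the shared core, so it does not bear directly on this change. What the other compounds do offer is a point of comparison: compound 1 `Cc1cccc(-c2noc(C3CC(=O)N(c4ccc(Cl)cc4)C3)n2)c1` and compound 2 `COc1cccc(-c2noc(C3CC(=O)N(c4ccc(Cl)cc4)C3)n2)c1` both carry the same 4-chlorophenyl on the amide-type nitrogen that compound 4 receives. In this assay compound 1 gives 170 nM, while compound 2 gives 4800 nM. Compound 4 keeps the 3-chlorophenyl of compound 3 on the other side of the core, where compound 1 has a methyl and compound 2 a methoxy on an aromatic carbon.

Compound 4 is therefore expected to return a measurable number, estimated at 600 nM, within a range from 120 nM to 4000 nM. That expected result would mean the step of an at least 16-fold lower number from compound 3 to compound 4 (1.22 log units; beyond the scatter), with its size left open by the limit of compound 3.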

Compound 4, half-maximal effective concentration: 140 nM
For compound 4 the middle estimate is 4.3-fold (0.63 log units) above the measured one, and the stated range covers the measured number.
By their numbers in this assay, from the lowest: compounds 4 and 1 (each within the scatter of the next); then compound 2. At a limit, above all of these: compound 3.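

In this assay, from the compounds shown here alone, the change at the amide-type nitrogen gives an at least 71-fold lower number from compound 3 to compound 4 (1.85 log units; beyond the scatter) and so turns a compound at the edge of the assay into one with a measurable number, though the real size of the step stays open, since the value of compound 3 is a limit: the limit of > 10000 nM in this assay, at which 1 of the 4 values shown sits. With 4-chlorophenyl kept on that nitrogen, chloro in place of methyl on an aromatic carbon gives a 1.2-fold lower number from compound 1 to compound 4 (0.08 log units; within the scatter) and so leaves the number within the usual scatter, whereas chloro in place of methoxy on an aromatic carbon gives a 34-fold lower number from compound 2 to compound 4 (1.54 log units; beyond the scatter) as a large step. Compound 4 thus links two single changes: in each of its pairs, with compound 2 and with compound 3, the partner that carries a methoxy needs far more compound for the effect.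

The step at the amide-type nitrogen changes both the group on the phenyl ring and its place there, and the compounds shown do not separate the two. They also leave open how an amine or a carboxylic acid would read in place of the chlorine of the 4-chlorophenyl.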